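This account rests on a few compounds, and the source may have more. Where it says the series, first, only, none or still open, it means among the compounds named here.

Compound 1 `COc1ccc(OC(=O)Nc2ccc([Se]C#N)cc2)cc1`: 41500 nM
Compound 2 `O=C(Nc1ccc([Se][Se]c2ccc(NC(=O)Oc3ccc(F)cc3)cc2)cc1)Oc1ccc(F)cc1`: 37600 nM

Within the data shown here, in a functional assay on CCRF-CEM cells (Homo sapiens) for cytotoxicity, read by MTT assay, with a stated time of 72 h (on this read-out lower numbers stand for stronger inhibition of growth and higher numbers for weaker inhibition of growth), compound 1 gives 41500 nM, the higher of the two numbers measured so far, while compound 2 gives 37600 nM; the two values lie within the scatter of each other, so nothing separates them. Compound 3 `N#C[Se]c1ccc(NC(=O)Oc2ccccc2)cc1` has not yet been measured. It differs from compound 1 by hydrogen in place of methoxy on an aromatic carbon. Among the measured compounds shown here, no measured pair in this set shows such a change, so the data give no guide to its size. The step from compound 1 to compound 3 is expected to be small and within the scatter, a 1.0-fold lower number from compound 1 to compound 3 (0.02 log units; within the scatter), in either direction. Compound 3 is therefore expected to give about 40000 nM in this assay, within a range from 15000 nM to 100000 nM.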

Compound 3, concentration for total growth inhibition: 48000 nM
The estimate for compound 3 lay 1.2-fold (0.08 log units) below the measured number; the range from low to high includes it.
By their numbers in this assay, from the lowest: compounds 2, 1 and 3 (each within the scatter of the next).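

In this assay, hydrogen in place of methoxy on an aromatic carbon, para to a large group, gives a 1.2-fold higher number from compound 1 to compound 3 (0.06 log units; within the scatter). This first measured pair for the change therefore shows that removing the methoxy group from this position leaves the number within the scatter. No supporting measurement bears on why the change has so little effect. Going by these compounds, whether an amine, a carboxylic acid or a longer chain at this position would move the number beyond the scatter remains open. Also open, on these data alone, is whether hydrogen in place of methoxy would stay this small on another core.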